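Swapping the Aryl on the Piperazine Nitrogen: Compound 3

The source may report more compounds than this note shows. Statements on the series, on what has been measured and on what is new or still open speak of the compounds shown alone.

The two measured compounds share one core and differ only in the aryl group on an amine nitrogen in a ring. Compound 1 `Nc1scc(CN2CCN(c3cccc(F)c3F)CC2)c1C(=O)c1ccc(Cl)cc1` gives -13% in a functional assay on CHO cells with adenosine receptor A1 (Homo sapiens) as the target, read by cAMP accumulation and immunoassay, with a stated time of 6 min, tested at 0.01 uM; on this read-out higher numbers stand for a weaker effect at the one concentration tested and lower numbers for a stronger effect. Compound 2 `Nc1scc(CN2CCN(c3c(F)cc(F)cc3F)CC2)c1C(=O)c1ccc(Cl)cc1` gives 4.2% in this assay, the highest of the two numbers, meaning the weaker effect of the pair at the single concentration; the step of a number 17.2 percentage points higher from compound 1 to compound 2 (beyond the scatter) sets the scale.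

Compound 3 `Nc1scc(CN2CCN(c3cc(Cl)ccc3Cl)CC2)c1C(=O)c1ccc(Cl)cc1` carries 2,5-dichlorophenyl in place of 2,4,6-trifluorophenyl on an amine nitrogen in a ring. Among the measured compounds shown here, the only step that bears on it is the aryl swap from compound 1 to compound 2, which moved the read-out modestly. A second aryl swap at the same place is therefore expected to move this assay by a similar modest amount, with the direction uncertain; compound 3 is estimated at -3%, within -25% to 19%, corresponding to an expected step of a number 7.2 percentage points lower from compound 2 to compound 3 (within the scatter).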

Compound 3, a percentage reported as activity, at one concentration (the size of the read-out at that concentration, not a potency): 13%
For compound 3 the middle estimate is 16 percentage points below the measured one; the measured number falls inside the stated range.
By their numbers in this assay, from the lowest: compound 1; then compounds 2 and 3 (each within the scatter of the next).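

In this assay, placing 2,5-dichlorophenyl where 2,4,6-trifluorophenyl stood on the amine nitrogen in a ring gives a number 8.8 percentage points higher from compound 2 to compound 3 (within the scatter) and so does not separate these two aryl groups on this read-out. Against 2,3-difluorophenyl the same group gives a number 26 percentage points higher from compound 1 to compound 3 (beyond the scatter) and thus leaves compound 1 apart from both compound 2 and compound 3, so the position is sensitive to the aryl group in at least this one comparison, even though chlorine and fluorine substitution are not separated by the step from compound 2. Nothing available explains why compound 1 stands apart.

As far as these compounds go, whether a methoxy group, a nitrile or an unsubstituted phenyl here would read like compound 1 or like compound 2 and compound 3 remains open. From the compounds shown here alone, with a single concentration and changes at this one place, potency and the rest of the shared core also remain open.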